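The source may hold more compounds than are shown below. What is called first, only, known or untested is meant among the compounds shown, and "the series" means these compounds.

Compound 2 `COc1ccc(C=c2s/c(=C3\C(=O)Nc4cc(F)ccc43)n(CCN(C)C)c2=O)cc1` sits second highest of the three numbers in a functional assay on NCI-H460 cells (Homo sapiens) for inhibition, read by MTT assay, with a stated time of 72 h (a lower number here means a stronger inhibitor, a higher number a weaker inhibitor), where compound 2 gives 2200 nM. Its nearest neighbour is compound 3 `CN(C)CCn1c(=O)c(=Cc2ccc(O)cc2)s/c1=C1\C(=O)Nc2ccc(F)cc21`, which in this assay gives 1270 nM, a gap that lies within the scatter of the measurement. Furthest away is compound 1 `CN(C)CCn1c(=O)c(=Cc2ccc(F)c(F)c2)s/c1=C1\C(=O)Nc2cc(F)ccc21`, which in this assay gives 6400 nM; the one recorded step, a 2.9-fold lower number from compound 1 to compound 2 (0.46 log units; beyond the scatter), separates these two.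

The next compound, compound 4 `COc1ccc(OC)c(C=c2s/c(=C3\C(=O)Nc4cc(F)ccc43)n(CCN(C)C)c2=O)c1`, differs from compound 2 in one place: 2,5-dimethoxyphenyl in place of 4-methoxyphenyl on a double-bonded chain carbon bound to an aromatic carbon. Among the measured compounds shown here, no measured step exchanges one methoxy-bearing phenyl for another, so the only step that bears on this change is the replacement of the 3,4-difluorophenyl by the 4-methoxyphenyl, a 2.9-fold lower number from compound 1 to compound 2 (0.46 log units; beyond the scatter), which was modest in size and only just beyond the scatter. That step does not tell how a second methoxy group on the same ring, with the first one moved, will read out.

On that basis the expected step from compound 2 to compound 4 in this assay is a 1.1-fold higher number from compound 2 to compound 4 (0.06 log units; within the scatter), which is to say no change that clearly exceeds the scatter. Compound 4 is therefore estimated at 2500 nM in this assay, with a range from 900 nM to 7000 nM.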

Compound 4, half-maximal inhibitory concentration: 7150 nM
Compound 4: the middle estimate sits 2.9-fold (0.46 log units) below what was measured; the measured number lies above the stated range.
By their numbers in this assay, from the lowest: compounds 3 and 2 (each within the scatter of the next); then compounds 1 and 4 (each within the scatter of the next).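

In this assay, the 4-methoxyphenyl group had looked like a gain over 3,4-difluorophenyl on the double-bonded chain carbon bound to an aromatic carbon (a 2.9-fold lower number from compound 1 to compound 2 (0.46 log units; beyond the scatter)), but 2,5-dimethoxyphenyl at the same place reverses that gain (a 3.3-fold higher number from compound 2 to compound 4 (0.51 log units; beyond the scatter)). Set against 3,4-difluorophenyl, the 2,5-dimethoxyphenyl group makes no change beyond the scatter (a 1.1-fold higher number from compound 1 to compound 4 (0.05 log units; within the scatter)), so among compound 1, compound 2 and compound 4 the presence of methoxy on the phenyl ring does not by itself go with the lower number, and compound 4 goes against any such reading. Nothing measured here gives a reason for the difference between these two methoxy-bearing phenyl groups.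

The compounds shown do not separate the effect of the second methoxy group from that of moving the first, since 2,5-dimethoxyphenyl differs from 4-methoxyphenyl in both respects. Going by these compounds, it also remains open how this place would respond to a phenyl ring carrying an ethoxy group, a dimethylamino group or a carboxylic acid.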